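Swapping fluoro for bromo on a shared thiazolylidene hydrazide scaffold

The source may hold more compounds than are shown below. What is called first, only, known or untested is meant among the compounds shown, and "the series" means these compounds.

Measured so far:
- compound 1, `O=C(CSc1nnnn1-c1ccccc1)N/N=c1/scc(-c2ccccc2)n1-c1ccccc1`: 52.1%
- compound 2, `O=C(CSc1nnnn1-c1ccccc1)N/N=c1/scc(-c2ccc(F)cc2)n1-c1ccccc1`: 74.9%

Both numbers come from a functional assay on C6 cells (Rattus norvegicus) for cytotoxicity, read by MTT assay, with a stated time of 24 h, tested at 6 ug/mL; a higher number here means a weaker effect of the compound at the concentration tested, a lower number a stronger effect. Going by the values given here, compound 2 holds the higher of the two numbers, and the only measured step, a number 22.8 percentage points higher from compound 1 to compound 2 (beyond the scatter), describes how it got there: the one change was fluoro in place of hydrogen on an aromatic carbon, and the read-out rose by an amount clearly beyond the scatter.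

Compound 3, `O=C(CSc1nnnn1-c1ccccc1)N/N=c1/scc(-c2ccc(Br)cc2)n1-c1ccccc1`, is the next compound to be measured. Its difference from compound 2 is bromo in place of fluoro on an aromatic carbon. Among the compounds with values here, no measured step exchanges one halogen for another, so the step from compound 1 to compound 2 is the only guide, and it bears on the question only indirectly: it shows that placing a halogen on this aromatic carbon moved the number upward, but it says nothing about whether a second, different halogen moves it further. The expectation for compound 3 is therefore a step of a number 0.9 percentage points lower from compound 2 to compound 3 (within the scatter), within the scatter, and an estimate for compound 3 in this assay of 74%, with a range from 55% to 90%.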

Compound 3, a percentage reported as activity, at one concentration (the size of the read-out at that concentration, not a potency): 61.8%
The estimate for compound 3 lay 12.2 percentage points above the measured number; measured number inside the range.
By their numbers in this assay, from the lowest: compounds 1 and 3 (each within the scatter of the next); then compound 2.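

In this assay, the two halogens do not behave as interchangeable at this aromatic carbon, para to a large group: bromo in place of fluoro gives a number 13.1 percentage points lower from compound 2 to compound 3 (beyond the scatter), so the change from 4-fluorophenyl to 4-bromophenyl matters even though each group is a single halogen atom with no hydrogen-bond donors or acceptors. Set against the hydrogen-bearing compound, bromo in place of hydrogen gives a number 9.7 percentage points higher from compound 1 to compound 3 (within the scatter), so the upward shift seen with fluoro is not a general result of placing a halogen here, and only fluoro has a step from hydrogen that lies beyond the scatter. No measurement of any property of these groups accompanies the numbers, so the reason for this difference stays unexplained.

The compounds shown leave open whether chloro, the halogen that would complete this small series, would sit with fluoro or with bromo, and whether a methyl, a methoxy or an amine on the same carbon would behave like hydrogen or like either halogen. They also leave open whether fluoro placed elsewhere on this six-membered ring would give a similar step.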